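A few compounds are considered here, and "the series" means these few. Any claim that something is new, unique, unknown or untested is made for them only; others in the source may bear on it.

In an assay on isolated protein for inhibition of protein deacetylase HDAC6 (Homo sapiens), read by fluorescence, with a stated time of 1 h, tested at 100 nM (on this read-out higher numbers stand for more inhibition at the one concentration tested (going by the name of the read-out) and lower numbers for less inhibition), compound 1, `O=C(/C=C/c1ccc(OCc2nc(C3CCN(Cc4ccccc4)CC3)no2)cc1)NO`, gives 71%. Compound 2, `Cc1cccc(CN2CCC(c3noc(COc4ccc(/C=C/C(=O)NO)cc4)n3)CC2)c1`, carries one change relative to compound 1, (methyl in place of hydrogen on an aromatic carbon), and in this assay compound 2 gives 73%, a step of a number 2 percentage points higher from compound 1 to compound 2 (within the scatter). Compound 3, `CN(Cc1nc(C2CCN(Cc3ccccc3)CC2)no1)c1ncc(/C=C/C(=O)NO)cn1`, has a core that differs from the core of compound 1 in more than one place, and the difference between the two cores is not broken down here; in this assay compound 3 gives 55%, the lowest of the three values, with both other compounds standing beyond the scatter above it.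

Compound 4, `Cc1ccc(CN2CCC(c3noc(CN(C)c4ncc(/C=C/C(=O)NO)cn4)n3)CC2)cc1`, has not been measured. It carries the same kind of change relative to compound 3 that compound 2 carries relative to compound 1, (methyl in place of hydrogen on an aromatic carbon), though here the methyl sits para to a large group, whereas in compound 2 it sits meta to a large group. The earlier step of a number 2 percentage points higher from compound 1 to compound 2 (within the scatter) stayed within the scatter, so a step of a number 2 percentage points higher from compound 3 to compound 4 (within the scatter) is expected for compound 4. On that basis compound 4 is estimated to give 57%, with a likely range from 45% to 68%.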

Compound 4, a percentage reported as inhibition, at one concentration (the size of the read-out at that concentration, not a potency): 60%
The estimate for compound 4 lay 3 percentage points below the measured number; measured number inside the range.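

In this assay, putting a 4-methylbenzyl group in place of the benzyl group amounts to a number 5 percentage points higher from compound 3 to compound 4 (within the scatter). Set beside the same change on the core of compound 1, the step looks alike on both cores: the same change on two cores in this assay, a number 2 percentage points higher (within the scatter) from compound 1 to compound 2 and a number 5 percentage points higher (within the scatter) from compound 3 to compound 4, 3 percentage points apart, within the scatter of two such steps. This shows that on these two cores the methyl leaves the reading within the usual spread of repeats, but it does not show that the methyl has any real effect on either core, nor does it tell how the change would behave on a third core, and the methyl stands para to a large group only in compound 4, so the two pairs do not test one identical placement.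

Still open, from the compounds shown here alone, is whether a different group at this place on the ring, such as a methoxy group, a chlorine atom or a trifluoromethyl group, would shift the reading beyond the scatter. Also open, going by these compounds, is how these single-concentration readings would translate into potency, since a percentage at one concentration is not a potency.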